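The source may report more compounds than this note shows. Statements on the series, on what has been measured and on what is new or still open speak of the compounds shown alone.

Of the compounds shown here, three of the shared core have been tested in a functional assay on MCF7 cells (Homo sapiens) for cytotoxicity, with a stated time of 72 h; on this read-out higher numbers stand for weaker inhibition and lower numbers for stronger inhibition. Compound 1 `C[C@H](NC(=O)c1cc(Cl)ccc1O)C(=O)Nc1ccc(C(F)(F)F)cc1` gives only a limit, > 12500 nM. Compound 2 `C[C@H](NC(=O)c1cc(Cl)ccc1O)C(=O)Nc1cccc(Cl)c1` likewise returns a limit, > 10000 nM. Compound 3 `Cc1ccc(NC(=O)[C@H](CC2CCCC2)NC(=O)c2cc(Cl)ccc2O)cc1` also sits at a limit, > 10000 nM, so on the numbers shown compound 3 stands at the same limit as compound 2 (the limit of > 10000 nM in this assay, at which 2 of the 3 values shown sit), while compound 1 sits at a different limit (the limit of > 12500 nM in this assay, at which 1 of the 3 values shown sits), and no number separates the three.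

Compound 4 `Cc1ccc(NC(=O)[C@H](C)NC(=O)c2cc(Cl)ccc2O)cc1` differs from compound 3 in one place: hydrogen in place of cyclopentyl on a saturated chain carbon, two bonds along the chain from an amide-type nitrogen and a carbonyl carbon. Compound 1 and compound 2 already carry this smaller side chain with other aryl amides and both come back as limits, so no step beyond the scatter is expected in this assay from the cut, in either direction. Compound 4 is therefore estimated to remain at or beyond the limit, with 15000 nM between 8000 nM and 50000 nM. The step that the limit leaves unreadable from compound 3 to compound 4 is expected to be essentially none.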

Compound 4, half-maximal inhibitory concentration: > 10000 nM
Compound 4 ended at the assay's limit; the forecaster's own chance of this, stated with the estimate: 85%; the middle value is on the limit's open side.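

In this assay compound 4 gives only a limit, > 10000 nM. The steps to compound 4 from compound 1, compound 2 and compound 3 cannot be read, as all four values are limits. The compounds shown leave open whether any of these side chains or aryl amides gives a measurable value in this assay.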